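The source may report more compounds than this note shows. Statements on the series, on what has been measured and on what is new or still open speak of the compounds shown alone.

Measured in a functional assay on PANC-1 cells (Homo sapiens) for inhibition, read by MTT assay, with a stated time of 24 h, tested at 10 uM; on this read-out lower numbers stand for less inhibition and higher numbers for more inhibition at the one concentration tested (going by the name of the read-out):
compound 1 `CC(C)=CCC/C(C)=C/CC1Cc2c(O)cc(=O)n(CCCO)c2CC1(C)C` gives 28.7%;
compound 2 `COc1ccc(OCCCOc2cc(=O)n(CCCO)c3c2CC(CC=C(C)C)C(C)(C)C3)cc1` gives 47.7%;
compound 3 `CC(C)=CCC/C(C)=C/CC1Cc2c(OCCCNC(=O)c3cccs3)cc(=O)n(CCCO)c2CC1(C)C` gives 72.8%.

Compound 3 stands highest of the three, and its gap to both compound 2 and compound 1 lies beyond the scatter. Among the compounds with values here, the one measured step that touches it, a number 44.1 percentage points higher from compound 1 to compound 3 (beyond the scatter), is large and concerns the group that now leaves. Compound 4 `COc1ccc(OCCCOc2cc(=O)n(CCCO)c3c2CC(C/C=C(\C)CCC=C(C)C)C(C)(C)C3)cc1` differs from compound 3 in that (4-methoxyphenoxy in place of ((thiophen-2-yl)carbonyl)amino on a saturated chain carbon, three bonds along the chain from an oxygen on an aromatic ring). Within the data shown here, no measured step covers this exchange directly; the only guide is compound 2, which carries the same entering group and gives 47.7%. The expected step is therefore downward, a number 22.8 percentage points lower from compound 3 to compound 4 (beyond the scatter). Compound 4 is estimated at 50%, with a range from 32% to 68%.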

Compound 4, a percentage reported as inhibition, at one concentration (the size of the read-out at that concentration, not a potency): 20%
Beside the measured number, compound 4's estimate is 30 percentage points above it; measured number below the stated range.
By their numbers in this assay, from the lowest: compounds 4 and 1 (each within the scatter of the next); then compound 2; then compound 3.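

In this assay, 4-methoxyphenoxy in place of ((thiophen-2-yl)carbonyl)amino gives a number 52.8 percentage points lower from compound 3 to compound 4 (beyond the scatter) and so shows that the two groups are far from interchangeable at this place. The added 3-methylbut-2-en-1-yl gives a number 27.7 percentage points lower from compound 2 to compound 4 (beyond the scatter) and so shows that the 4-methoxyphenoxy result depends on the other chain. With 3-(4-methoxyphenoxy)propyl in place of hydrogen on the oxygen, the step is a number 8.7 percentage points lower from compound 1 to compound 4 (within the scatter) and shows no gain over the free hydroxy compound.

On these data alone, whether an amine or a carboxylic acid in place of ((thiophen-2-yl)carbonyl)amino would hold the level of compound 3 remains open. No evidence at hand accounts for these steps.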